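Chloro for fluoro: expectation for compound 4

The source may report more compounds than this note shows. Statements on the series, on what has been measured and on what is new or still open speak of the compounds shown alone.

In a functional assay on HeLa cells (Homo sapiens) for antiproliferative activity, read by cell counting, with a stated time of 2 days (a lower number here means a stronger inhibitor, a higher number a weaker inhibitor), compound 1 (`COc1cc(C(=O)c2sc(Nc3ccc(F)cc3)nc2N)cc(OC)c1OC`) gives 440 nM as the second highest of three numbers. Compound 3 (`COc1cccc(C(=O)c2sc(Nc3ccccc3)nc2N)c1`) stands higher at 1700 nM and compound 2 (`COc1ccc(Nc2nc(N)c(C(=O)c3ccc(Cl)cc3)s2)cc1`) lower at 83 nM in the same read-out. Unmeasured compound 4 (`COc1cc(C(=O)c2sc(Nc3ccc(Cl)cc3)nc2N)cc(OC)c1OC`) carries chloro in place of fluoro on an aromatic carbon, para to a large group (chloro in place of fluoro on an aromatic carbon). Within the data shown here, no measured pair differs in one place only, so the series offers no direct guide to this change. No step beyond the scatter is expected in this assay and no clear direction can be given. The estimated 1.2-fold lower number from compound 1 to compound 4 (0.06 log units; within the scatter) therefore stays small. Compound 4 is expected at 380 nM within an estimated range from 130 nM to 1100 nM for now.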

Compound 4, half-maximal inhibitory concentration: 180 nM
The estimate for compound 4 lay 2.1-fold (0.32 log units) above the measured number; the measured number falls inside the stated range.
By their numbers in this assay, from the lowest: compound 2; then compound 4; then compound 1; then compound 3.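

In this assay the series gains its first comparison that differs in one place: chloro in place of fluoro on an aromatic carbon, para to a large group, gives a 2.4-fold lower number from compound 1 to compound 4 (0.39 log units; beyond the scatter) and so a modest step beyond the scatter. This position therefore responds to the choice of halogen, with 4-chlorophenyl ahead of 4-fluorophenyl in the core of compound 1. Nothing at hand accounts for this step.

From the compounds shown here alone, whether bromo, trifluoromethyl or an amine at this place would lower the number further stays open. Also open, going by these compounds, is whether the step holds when the rest of compound 1 changes.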